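From ethoxy to 2,2,2-trifluoroethoxy in a small series

A few compounds are considered here, and "the series" means these few. Any claim that something is new, unique, unknown or untested is made for them only; others in the source may bear on it.

In a functional assay on SiHa cells (Homo sapiens) for antiproliferative activity, read by CCK-8 assay, with a stated time of 72 h (on this read-out higher numbers stand for weaker inhibition and lower numbers for stronger inhibition), compound 1 `COc1cc(-c2ncncc2-c2ccc(SC)cc2)cc(OC)c1OC` gives 560 nM, compound 2 `CCSc1ccc(-c2cncnc2-c2cc(OC)c(OC)c(OC)c2)cc1` gives 1030 nM and compound 3 `CCOc1ccc(-c2cncnc2-c2cc(OC)c(OC)c(OC)c2)cc1` gives 640 nM. Compound 3 therefore sits within the scatter of both others, and the three values cannot be ranked. The next change leads to compound 4 `COc1cc(-c2ncncc2-c2ccc(OCC(F)(F)F)cc2)cc(OC)c1OC`: trifluoromethyl in place of methyl on a saturated chain carbon bound to an oxygen on an aromatic ring. It places trifluoromethyl in place of methyl on a saturated chain carbon bound to an oxygen on an aromatic ring.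

Going by the values given here, three measured steps bear on this. Lengthening the sulfur chain gave a 1.8-fold higher number from compound 1 to compound 2 (0.26 log units; within the scatter), while swapping the sulfur-linked groups for ethoxy gave a 1.1-fold higher number from compound 1 to compound 3 (0.06 log units; within the scatter) and a 1.6-fold lower number from compound 2 to compound 3 (0.21 log units; within the scatter). All three stay within the scatter, so this end of the molecule has so far tolerated change in this assay. Among the compounds with values here, no measured compound carries fluorine, however, so the precedent is indirect. The expected change is small, with a slightly higher number and no clear shift beyond the scatter, estimated as a 1.3-fold higher number from compound 3 to compound 4 (0.10 log units; within the scatter). For compound 4 the estimated value is 800 nM, with an expected range from 350 nM to 1800 nM.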

Compound 4, half-maximal inhibitory concentration: 33300 nM
Compound 4: middle estimate off by 42-fold (1.62 log units), on the low side; measured number outside the range, above it.
By their numbers in this assay, from the lowest: compounds 1, 3 and 2 (each within the scatter of the next); then compound 4.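

In this assay, going by these compounds alone, the exchange of methyl for trifluoromethyl on a saturated chain carbon bound to an oxygen on an aromatic ring gave a 52-fold higher number from compound 3 to compound 4 (1.72 log units; beyond the scatter) and so marks the first large change at this position. The same gap appears against the two sulfur-linked compounds, with a 32-fold higher number from compound 2 to compound 4 (1.51 log units; beyond the scatter) and a 59-fold higher number from compound 1 to compound 4 (1.77 log units; beyond the scatter), so the tolerance seen among methylsulfanyl, ethylsulfanyl and ethoxy does not extend to 2,2,2-trifluoroethoxy. Nothing measured here accounts for this jump.

The compounds shown leave open whether the weaker inhibition needs the full trifluoromethyl or would already appear with difluoroethoxy. They also leave open how a longer chain such as propoxy, or an amine or a carboxylic acid at the end of the chain, would read out here.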